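This account rests on a few compounds, and the source may have more. Where it says the series, first, only, none or still open, it means among the compounds named here.

Measured compounds in an in vitro functional assay on cells (Fibroblast) for agonist activity at Alpha-1B adrenergic receptor (Homo sapiens); a higher number here means that more compound is needed for the effect, a lower number that less compound is needed:
Compound 1 `Cn1ncnc1-c1ccccc1NCC1=NCCN1` gives 39.8 nM in this assay.
Compound 2 `Cc1n[nH]c(-c2ccccc2NCC2=NCCN2)n1` gives only a limit of the assay in this assay, < 5020 nM.
Compound 3 `Cn1cccc1-c1ccccc1NCC1=NCCN1` likewise gives only a limit of the assay in this assay, < 100000 nM.

Compound 3 therefore stands without a readable number; it sits at the limit of < 100000 nM in this assay, at which 1 of the 3 values shown sits, and compound 2 sits at the limit of < 5020 nM in this assay, at which 1 of the 3 values shown sits. The steps that reach compound 3, a step that the limit leaves unreadable from compound 1 to compound 3 and a step that the two limits leave unreadable from compound 2 to compound 3, cannot be sized for the same reason, and a step that the limit leaves unreadable from compound 1 to compound 2 is equally unreadable.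

Compound 4 `Cc1ccc(-c2ccccc2NCC2=NCCN2)n1C` is not yet measured. It differs from compound 3 by methyl in place of hydrogen on an aromatic carbon. Within the data shown here, no measured step exchanges hydrogen for methyl on this five-membered ring; the measured steps all replace the whole ring and none of them yields a size. There is thus nothing in the shown data to predict a direction for this change, and compound 4 is expected to stay close to where compound 3 stands, with a step that the limit leaves unreadable from compound 3 to compound 4 taken as no step beyond the scatter. Compound 4 is estimated at 20000 nM, within 2000 nM to 100000 nM, with a real chance that only a limit is again reported.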

Compound 4, half-maximal effective concentration: < 100000 nM
Compound 4: no number, only a limit; the forecaster's own chance of this, stated with the estimate: 60%; the middle value is on the limit's open side.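

Compound 4 gives < 100000 nM in this assay, which is a limit of the assay; compound 3 also gives only a limit, and no new step can be read between them. The compounds shown leave open whether methyl in place of hydrogen on an aromatic carbon changes the concentration needed.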